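Swapping chloro for bromo on a potent aryl ketone

This account rests on a few compounds, and the source may have more. Where it says the series, first, only, none or still open, it means among the compounds named here.

Measured in a functional assay on MCF7 cells (Homo sapiens) for cytotoxicity, read by MTT assay, with a stated time of 96 h; on this read-out higher numbers stand for weaker inhibition and lower numbers for stronger inhibition:
- compound 1 `COc1cc(C(=O)c2cn(-c3cccc(Cl)c3)cc2-c2ccccc2)cc(OC)c1OC`: 150 nM
- compound 2 `COc1cc(C(=O)c2cn(-c3ccccc3)cc2-c2ccccc2Cl)cc(OC)c1OC`: 76 nM
- compound 3 `COc1cc(C(=O)c2cn(-c3ccccc3)cc2-c2cccc(Cl)c2)cc(OC)c1OC`: 540 nM

Of these three, compound 3 gives the highest number, 540 nM, and so shows the weakest inhibition. Compound 1 lies nearest to it at 150 nM, while compound 2 lies furthest at 76 nM.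

The next compound, compound 4 `COc1cc(C(=O)c2cn(-c3ccccc3)cc2-c2cccc(Br)c2)cc(OC)c1OC`, has bromo in place of chloro on an aromatic carbon, turning 3-chlorophenyl into 3-bromophenyl (bromo in place of chloro on an aromatic carbon). Among the measured compounds shown here, only one measured step concerns this substituent: a 7.1-fold higher number from compound 2 to compound 3 (0.85 log units; beyond the scatter). That step is sizeable, but it moves the chloro group to another position and does not exchange one halogen for another. It shows that the position of the chloro group matters here, but it gives no measure of what a change of halogen does. For the measured compounds named here, no measured pair makes that exchange, and the position stays the same in this change. No step beyond the scatter is therefore expected in this assay, and any drift could go in either direction. The expected result is a 1.2-fold lower number from compound 3 to compound 4 (0.08 log units; within the scatter), which would leave the number close to where it stands. For compound 4 the estimated value is 450 nM, with an expected range of 180 nM to 1100 nM.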

Compound 4, half-maximal inhibitory concentration: 950 nM
Compound 4: middle estimate off by 2.1-fold (0.32 log units), on the low side; the range from low to high includes it.
By their numbers in this assay, from the lowest: compounds 2 and 1 (each within the scatter of the next); then compounds 3 and 4 (each within the scatter of the next).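

The exchange of chloro for bromo on this aromatic carbon gives a 1.8-fold higher number from compound 3 to compound 4 (0.25 log units; within the scatter), so in this assay compound 3 and compound 4 cannot be told apart. Among the compounds shown here, the earlier compounds showed only what moving the chloro group does, whereas this pair is the first to exchange one halogen for another while the place stays the same, and the 3-bromophenyl group also stands well apart from the 2-chlorophenyl group, with a 13-fold higher number from compound 2 to compound 4 (1.10 log units; beyond the scatter). Nothing available here offers an explanation for either result, whether for the lack of separation between the two halogens or for the large gap to compound 2.

The compounds shown leave open whether the same exchange of chloro for bromo on the 2-chlorophenyl group of compound 2, or on the 3-chlorophenyl group of compound 1, would also stay within the scatter. They also leave open how a group other than a halogen, such as a methoxy group or an amine, would read in the place that chloro and bromo share in compound 3 and compound 4.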